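The compounds below may be only part of what the source reports. "The series", "measured", "known", "first", "only" and "open" are said of these compounds alone.

Working notes on the shared core. Compound 1 `O=[N+]([O-])c1cn2c(n1)OC[C@@H](OC/C=C/c1ccc(OCc3ccccc3)cc1)C2`, compound 2 `O=[N+]([O-])c1cn2c(n1)OC[C@@H](Oc1cc(-c3ccc(OC(F)(F)F)cc3)ncn1)C2` and compound 3 `O=[N+]([O-])c1cn2c(n1)OC[C@@H](OCCCc1ccc(OC(F)(F)F)cc1)C2` have been measured in a physicochemical assay for solubility, read by HPLC, at pH 7; on this read-out lower numbers stand for lower solubility and higher numbers for higher solubility. Compound 1 gives 0.06 ug/mL. Compound 2 gives 0.88 ug/mL. Compound 3 gives 11 ug/mL, the highest of the three numbers; its nearest neighbour is compound 2 and its furthest is compound 1, both gaps lying beyond the scatter. Among the measured compounds shown here, no pair of measured compounds differs in only one place, so no single step can be read off the measured set.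

Compound 4 `O=[N+]([O-])c1cn2c(n1)OC[C@@H](OCCCc1ccc(-c3ccc(OC(F)(F)F)cc3)cc1)C2` is not yet measured in this assay. It differs from compound 3 in one place: 4-(trifluoromethoxy)phenyl in place of trifluoromethoxy on an aromatic carbon. A larger group thus enters where a smaller one leaves, and one further six-membered aromatic ring of carbon only is added. The step from compound 3 to compound 4 is expected to run downward and to exceed the scatter, estimated at a 22-fold lower number from compound 3 to compound 4 (1.34 log units; beyond the scatter); for comparison, compound 2, which also carries a second aromatic ring, gives 0.88 ug/mL. Compound 4 is expected to give 0.5 ug/mL, with a range from 0.1 ug/mL to 3 ug/mL.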

Compound 4, solubility: 1.7 ug/mL
Compound 4: middle estimate off by 3.4-fold (0.53 log units), on the low side; the measured number falls inside the stated range.
By their numbers in this assay, from the lowest: compound 1; then compounds 2 and 4 (each within the scatter of the next); then compound 3.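

At this place, on an aromatic carbon para to a large group, the series now has its first readable single change in this assay: 4-(trifluoromethoxy)phenyl in place of trifluoromethoxy gives a 6.5-fold lower number from compound 3 to compound 4 (0.81 log units; beyond the scatter), a step beyond the scatter. Since the entering group still carries trifluoromethoxy, the count changes by one further six-membered aromatic ring of carbon only, and the position therefore accepts this larger group with a measurable fall in the number. No available measurement bears on what lies behind this step.

Still open, as far as these compounds go, is whether a pyridine ring in place of the added ring of carbon only, or a morpholine at the same place, would give a different number. Also open, from the compounds shown here alone, is whether the same change gives a step of similar size on a longer chain.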